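The source may report more compounds than this note shows. Statements on the series, on what has been measured and on what is new or still open speak of the compounds shown alone.

Working notes on the series. Compound 1 (`COc1cc(-c2nn(-c3cccc(NC(=O)Nc4ccc(Cl)c(Cl)c4)c3)cc2-c2ccncc2)ccc1Cl`) gives > 50000 nM in a functional assay on K562 cells (Homo sapiens) for inhibition, read by sulforhodamine B assay, with a stated time of 48 h (on this read-out lower numbers stand for higher toxicity in this test and higher numbers for lower toxicity in this test), and this is a limit. Compound 2 (`COc1cc(-c2nn(-c3cccc(NC(=O)Nc4cccc(C(F)(F)F)c4)c3)cc2-c2ccncc2)ccc1Cl`) gives > 50000 nM in this assay and this is also a limit. Compound 3 (`COc1cc(-c2nn(-c3cccc(NC(=O)c4ccc(Cl)c(C(F)(F)F)c4)c3)cc2-c2ccncc2)ccc1Cl`) gives > 32500 nM in this assay and this too is a limit, so compound 3 has no numerical position in the series.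

The next change leads to compound 4 (`COc1cc(-c2nn(-c3cccc(NC(=O)c4ccccc4)c3)cc2-c2ccncc2)ccc1Cl`) and is phenyl in place of 4-chloro-3-(trifluoromethyl)phenyl on a carbonyl carbon with phenyl in place of 4-chloro-3-(trifluoromethyl)phenyl on a carbonyl carbon. The closest measured changes are a step that the two limits leave unreadable from compound 1 to compound 3 and a step that the two limits leave unreadable from compound 2 to compound 3 and both reach the same carbonyl carbon. The remaining one is a step that the two limits leave unreadable from compound 1 to compound 2 and it gives no size either. Among the compounds with values here, no measured step therefore supports a size or direction, and no shift beyond the scatter is expected. Another limit is the likeliest report.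

The estimated step is a step that the limit leaves unreadable from compound 3 to compound 4 in this assay and it is only an expectation. Compound 4 is expected at about 50000 nM with an estimated range from 25000 nM to 100000 nM in this assay if a number is reported.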

Compound 4, concentration lethal to 50% of the cells: > 100000 nM
Compound 4: no number, only a limit (the forecaster's own chance of this, stated with the estimate: 85%); at least 2.0-fold (0.30 log units) between middle value and limit.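

Compound 4 gives > 100000 nM in this assay, and this is a limit. With all four values being limits, none of the steps to compound 4 from compound 1, compound 2 or compound 3 can be read. The compounds shown leave open whether any of these changes on the carbonyl carbon alters toxicity in this test.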